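The compounds below may be only part of what the source reports. "The series", "measured", "known", "first", "only" and "open" are said of these compounds alone.

Measured so far:
Compound 1, `CC(C)(C)OC(=O)N1CCC(O[C@H]2CC[C@H](Oc3cnc(S(C)(=O)=O)cn3)CC2)CC1` — in a functional assay on isolated protein for agonist activity at Glucose-dependent insulinotropic receptor (Rattus norvegicus), read by HTRF and cAMP accumulation (a lower number here means a smaller maximal response, a higher number a larger maximal response), compound 1 gives 110%.
Compound 2, `CC(C)(C)OC(=O)N1CCC(O[C@H]2CC[C@H](Oc3ccc(S(C)(=O)=O)nn3)CC2)CC1` — in the same assay compound 2 gives 86%.

Among the measured compounds shown here, compound 1 stands highest of the two numbers so far. For the measured compounds named here, the only step measured, a number 24 percentage points lower from compound 1 to compound 2 (beyond the scatter), went with 6-(methylsulfonyl)pyridazin-3-yl in place of 5-(methylsulfonyl)pyrazin-2-yl on an oxygen on a saturated carbon; this is a modest step, beyond the scatter.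

Compound 3, `CS(=O)(=O)c1cnc(O[C@H]2CC[C@H](OC3CCN(C(=O)C4(C(F)(F)F)CC4)CC3)CC2)cn1`, keeps the core of compound 1 and differs from it in one place: 1-(trifluoromethyl)cyclopropyl in place of tert-butoxy on a carbonyl carbon. This change sits on the carbonyl carbon, a different place from the one varied in the measured step, so that step does not bear directly on it; it only shows that a modest shift is possible within this series. Nothing measured points to a direction for compound 3. Compound 3 is therefore expected to show no step beyond the scatter, a number 10 percentage points lower from compound 1 to compound 3 (within the scatter). The estimate for compound 3 is 100%, in a range from 80% to 120%.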

Compound 3, largest response reached (Emax), in percent of the reference or control that the assay uses: 140%
Compound 3: the middle estimate sits 40 percentage points below what was measured, outside the stated range (above it).
By their numbers in this assay, from the lowest: compound 2; then compound 1; then compound 3.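

In this assay, the group on the carbonyl carbon, whose other neighbour is the amide-type nitrogen in a ring, turns out to matter for the maximal response: 1-(trifluoromethyl)cyclopropyl in place of tert-butoxy gives a number 30 percentage points higher from compound 1 to compound 3 (beyond the scatter). The earlier compounds varied only the group on the oxygen on a saturated carbon, where the one step read was a number 24 percentage points lower from compound 1 to compound 2 (beyond the scatter), so this is the first step shown at the carbonyl carbon and the first one upward. The change removes an oxygen and brings in a three-membered ring and fluorine together, a single step cannot separate these differences, and nothing measured here accounts for the rise.

The compounds shown leave open whether the rise would persist with a plain cyclopropyl group, a tert-butyl group placed directly on the carbonyl carbon, or an amine at that position. They also leave open whether 1-(trifluoromethyl)cyclopropyl would have the same effect alongside the 6-(methylsulfonyl)pyridazin-3-yl group of compound 2.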